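A Fluoro Atom Where a Trifluoromethyl Once Stood

The source may report more compounds than this note shows. Statements on the series, on what has been measured and on what is new or still open speak of the compounds shown alone.

Compound 1 `COc1cc(C(F)(F)F)cc(C(F)(F)F)c1C(=O)NC1(c2ccccc2)CCCN(C(=O)c2ccccc2)C1`: a limit of the assay, > 10000 nM
Compound 2 `CN1CCCC(NC(=O)c2ccc(C(F)(F)F)cc2C(F)(F)F)(c2ccccc2)C1`: 540 nM
Compound 3 `CN1CCCC(NC(=O)c2ccc(C(F)(F)F)cc2)(c2ccccc2)C1`: a limit of the assay, > 10000 nM

Of the compounds shown here, three share a core and have been tested in an assay on cells for inhibition of sodium- and chloride-dependent glycine transporter 1 (Homo sapiens); on this read-out higher numbers stand for an effect only at larger amounts of compound and lower numbers for an effect already at smaller amounts. Compound 2 gives 540 nM. For compound 3 only a limit of the assay is known, > 10000 nM. For compound 1 the result is likewise a limit, > 10000 nM. Two of the three values therefore sit at the limit of > 10000 nM in this assay, at which 2 of the 3 values shown sit, and compound 3 stands among these two, with compound 2 as the only numbered value.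

Going by the values given here, the one measured step that changes a single group is an at least 18-fold higher number from compound 2 to compound 3 (1.26 log units; beyond the scatter). Removing a trifluoromethyl group thus costs a large amount of potency, though how much beyond the limit cannot be told.

Compound 4 `CN1CCCC(NC(=O)c2ccc(C(F)(F)F)cc2F)(c2ccccc2)C1` has not yet been measured. It differs from compound 3 by fluoro in place of hydrogen on an aromatic carbon. A fluoro group is much smaller than the trifluoromethyl group whose loss marked the step from compound 2 to compound 3, so only part of that loss might be recovered, if any. Compound 4 is therefore estimated at 5000 nM, with an expected range from 1500 nM to 20000 nM. This estimated step, an at least 2.0-fold lower number from compound 3 to compound 4 (0.30 log units; that floor lies within the scatter), may well end at a limit again.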

Compound 4, half-maximal effective concentration: 9900 nM
Estimate against measurement, compound 4: 2.0-fold (0.30 log units) below; the measured number falls inside the stated range.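

Replacing trifluoromethyl with fluoro on this aromatic carbon, ortho to a large group and meta to a trifluoromethyl group, gives an 18-fold higher number from compound 2 to compound 4 (1.26 log units; beyond the scatter), so in this assay a single fluorine does not do what the trifluoromethyl group does here. Compound 3, which carries hydrogen at this place, remains a limit of the assay at > 10000 nM. Going from hydrogen to fluoro gives a number no higher from compound 3 to compound 4 (the limit leaves the size open), and whether fluoro improves on hydrogen at all cannot be read, because this step starts from a limit rather than a number: the limit of > 10000 nM in this assay, at which 2 of the 4 values shown sit.

On these data alone, whether a chloro, methyl or methoxy group on this same carbon would bring the number closer to that of compound 2 stays open, and with it how much of the trifluoromethyl group's effect another group at this place can match. Also open, as far as these compounds go, is whether this trifluoromethyl group could be kept while the other trifluoromethyl group, the one that all three of compounds 2, 3 and 4 carry, gives way to a chloro group or a nitrile.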